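Removing One Fluoro Group: From Compound 1 to Compound 3

The source may report more compounds than this note shows. Statements on the series, on what has been measured and on what is new or still open speak of the compounds shown alone.

Measured compounds:
Compound 1 `CCC(C)(C)/N=c1\c(O)c(O)\c1=N/Cc1ccc(F)c(F)c1` — 1600 nM
Compound 2 `CCC(C)(C)Nc1c(NCc2c(C)cc(Cl)cc2Cl)c(=O)c1=O` — 100 nM

In a functional assay for inhibition, with Rattus norvegicus as the target (a higher number here means a weaker inhibitor, a lower number a stronger inhibitor), compound 1 gives 1600 nM, the highest of the two numbers and thus the weaker inhibition of the pair. Compound 2 gives 100 nM, a far lower number, and the gap lies beyond the scatter. The two compounds differ in several places at once, so these numbers alone cannot say which part of the molecule accounts for the gap.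

Compound 3 `CCC(C)(C)/N=c1\c(O)c(O)\c1=N/Cc1ccc(F)cc1` has not yet been measured. It differs from compound 1 in a single place: hydrogen in place of fluoro on an aromatic carbon. Among the measured compounds shown here, no measured pair shows what such a change does on this core, so the expectation rests on the size of the change alone. Swapping one fluorine for hydrogen is a small alteration, and the expected step is a 1.3-fold higher number from compound 1 to compound 3 (0.10 log units; within the scatter), not clearly beyond the scatter and, if anything, toward a slightly higher number. Compound 3 is therefore expected to give about 2000 nM in this assay, with a likely range from 800 nM to 5000 nM.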

Compound 3, half-maximal inhibitory concentration: 360 nM
Compound 3: the middle estimate sits 5.6-fold (0.74 log units) above what was measured, outside the stated range (below it).
By their numbers in this assay, from the lowest: compound 2; then compound 3; then compound 1.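

In this assay, hydrogen in place of fluoro on an aromatic carbon gives a 4.4-fold lower number from compound 1 to compound 3 (0.65 log units; beyond the scatter), a step beyond the scatter. Among the compounds shown here, this is the first change on the core of compound 1 that can be read on its own, and it shows that the fluoro group removed here, which stood ortho to a fluoro group and meta to a large group, is not needed for inhibition: the compound with hydrogen at that place is the stronger inhibitor, and the loss of one heavy atom is enough to move the number clearly. No measurement at hand explains why this change lowers the number.

The compounds shown leave open whether the remaining fluoro group helps or hurts, and whether the gain belongs to hydrogen itself or would also appear with a methoxy group or a nitrile at the same place. On these data alone, compound 2 differs from compound 3 in several places at once, so the separate share of its chloro and methyl groups, and of its different ring substitution, also remains unknown.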